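This account rests on a few compounds, and the source may have more. Where it says the series, first, only, none or still open, it means among the compounds named here.

The measured compounds and their values in a functional assay on SK-OV-3 cells (Homo sapiens) for inhibition, read by CCK-8 assay, with a stated time of 70 h; on this read-out higher numbers stand for weaker inhibition and lower numbers for stronger inhibition:

Compound 1, `COc1ccc(COc2ccc(OCCOCCNC3CCCC3)cc2)cc1`: 15700 nM
Compound 2, `c1ccc(COc2ccc(OCCOCCNC3CCOC3)cc2)cc1`: 48000 nM
Compound 3, `CC(C)(C)OC(=O)n1ccc(NCCOCCOc2ccc(OCc3ccccc3)cc2)c1`: 13000 nM

Among these three numbers compound 1 stands second highest. Its nearest neighbour is compound 3, whose number is lower by a margin that falls within the scatter, so the two cannot be told apart on this evidence. Compound 2 lies furthest from compound 1, with a higher number by a margin beyond the scatter, which marks compound 2 as the weaker inhibitor of that pair. For the measured compounds named here, no two of the measured compounds differ in a single place, so no measured step is available to guide the next comparison.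

Compound 4, `COC(=O)c1ccccc1COc1ccc(OCCOCCNC2CCCC2)cc1`, has not yet been tested in this assay. Compared with compound 1 the change is 2-(methoxycarbonyl)phenyl in place of 4-methoxyphenyl on a saturated chain carbon bound to an oxygen on an aromatic ring. The shared core of compound 1 is otherwise kept. Going by the values given here, since the measured compounds offer no precedent for this exchange, the account treats the step from compound 1 to compound 4 as most likely to stay within the scatter, with no direction favoured. On that basis compound 4 is expected to give about 15000 nM, with a plausible range from 6000 nM to 40000 nM. This estimate corresponds to an expected step of a 1.0-fold lower number from compound 1 to compound 4 (0.02 log units; within the scatter), a change not beyond the scatter.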

Compound 4, half-maximal inhibitory concentration: > 100000 nM
Compound 4 ended at the assay's limit (the forecaster's own chance of this, stated with the estimate: 15%); middle value at least 6.6-fold (0.82 log units) from the limit.
By their numbers in this assay, from the lowest: compounds 3 and 1 (each within the scatter of the next); then compound 2. At a limit, above all of these: compound 4.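

In this assay compound 4 gives > 100000 nM, which is a limit of the assay and not a number. For the compounds shown here, replacing 4-methoxyphenyl with 2-(methoxycarbonyl)phenyl on a saturated chain carbon bound to an oxygen on an aromatic ring gives the first step that can be read in one place, an at least 6.3-fold higher number from compound 1 to compound 4 (0.80 log units; beyond the scatter), and it shows that the aromatic group at this position cannot be exchanged freely while inhibition is kept. From the compounds shown here alone, only the smallest possible size of this step can be read, and its true size remains unknown: the limit of > 100000 nM in this assay, at which 1 of the 4 values shown sits.

The two group names differ both in the substituent and in its number on the ring, so this single step cannot separate the effect of the methoxycarbonyl group from the effect of where it sits. Going by these compounds, it also remains open whether a carboxylic acid in place of the methoxycarbonyl group, or a plain phenyl at the same position with the rest of compound 1 kept, would stay within the scatter of compound 1 or also lose inhibition.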